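An aryl exchange on the aromatic nitrogen: what to expect

The source may hold more compounds than are shown below. What is called first, only, known or untested is meant among the compounds shown, and "the series" means these compounds.

Compound 1 `COc1ccc(-n2nncc2CN2C(=O)C3(C(C#N)=C(N)Oc4c(N)cc5nc6ccccc6nc5c43)c3ccccc32)cc1`: in an ADME assay on HUVEC cells (Homo sapiens) for antiproliferative activity, read by MTT assay, with a stated time of 48 h (on this read-out lower numbers stand for stronger inhibition and higher numbers for weaker inhibition), compound 1 gives > 50000 nM, a limit of the assay.
Compound 2 `COc1ccc(OC)c(-n2nncc2CN2C(=O)C3(C(C#N)=C(N)Oc4c(N)cc5nc6ccccc6nc5c43)c3ccccc32)c1`: in this assay compound 2 gives > 50000 nM, again a limit.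
Compound 3 `N#CC1=C(N)Oc2c(N)cc3nc4ccccc4nc3c2C12C(=O)N(Cc1cnnn1-c1ccc(F)c(Cl)c1)c1ccccc12`: in this assay compound 3 gives > 50000 nM, also a limit.

Compound 3 therefore stands at the limit of this assay, as shown by the limit of > 50000 nM in this assay, at which 3 of the 3 values shown sit. No measured value among the three is a number. The step that the two limits leave unreadable from compound 1 to compound 2, the step that the two limits leave unreadable from compound 1 to compound 3 and the step that the two limits leave unreadable from compound 2 to compound 3 are all unreadable, so changing the aryl group on the aromatic nitrogen has not yet produced a readable effect in this assay.

Compound 4 `N#CC1=C(N)Oc2c(N)cc3nc4ccccc4nc3c2C12C(=O)N(Cc1cnnn1-c1ccc(Cl)cc1[N+](=O)[O-])c1ccccc12` differs from compound 3 in one place: 4-chloro-2-nitrophenyl in place of 3-chloro-4-fluorophenyl on an aromatic nitrogen. All three measured steps bear on it, since each exchanges the same aryl group on the same aromatic nitrogen, and each left the value at the limit. The reader therefore expects no step beyond the scatter, and expects compound 4 to sit at the limit as well; the estimated step that the limit leaves unreadable from compound 3 to compound 4 is expected to be unreadable. Compound 4 is estimated at 70000 nM, with a range from 25000 nM to 200000 nM.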

Compound 4, half-maximal inhibitory concentration: > 50000 nM
Compound 4: a limit, no number (the forecaster's own chance of this, stated with the estimate: 85%); the middle value is on the limit's open side.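

In this assay compound 4 gives > 50000 nM, a limit and not a number. Its steps from compound 1, compound 2 and compound 3 therefore cannot be read. The compounds shown leave open whether these four aryl groups on the aromatic nitrogen differ at all in this assay, since all four compounds share one limit: the limit of > 50000 nM in this assay, at which 4 of the 4 values shown sit.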